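Carboxylic acid analogues of a shared core against inositol hexakisphosphate kinase 3

The source may report more compounds than this note shows. Statements on the series, on what has been measured and on what is new or still open speak of the compounds shown alone.

Of the compounds shown here, two on a shared core have been measured in an assay for inhibition of inositol hexakisphosphate kinase 3 (Homo sapiens), read by colorimetric assay, coupled enzyme assay and malachite green, with a stated time of 120 min, in the presence of a further agent that is not named here; on this read-out higher numbers stand for weaker inhibition and lower numbers for stronger inhibition. Compound 1 `CNC(=O)c1ccc2noc(-c3ccccc3)c2c1` carries a methylamide and an unsubstituted phenyl; in this assay compound 1 gives 6830 nM. Compound 2 `O=C(O)c1ccc2noc(-c3ccc(N4CCCCC4)cc3)c2c1` carries a carboxylic acid and a phenyl bearing piperidin-1-yl; in this assay compound 2 gives 1790 nM. Compound 2 thus holds the lower of the two numbers, and the gap to compound 1 lies beyond the usual scatter, though the two compounds differ in two places at once, so the gap cannot be assigned to either change alone.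

Compound 3 `O=C(O)c1ccc2noc(-c3ccc(NC(=O)c4ccncn4)cc3)c2c1` keeps the carboxylic acid of compound 2 and alters only the group on the phenyl: ((pyrimidin-4-yl)carbonyl)amino in place of piperidin-1-yl on an aromatic carbon. Among the compounds with values here, no measured pair shows what such an exchange does on this core. The carboxylic acid, which accompanies the lower number of compound 2, is retained, so compound 3 is expected to stay near compound 2, with a step from compound 2 to compound 3 of a 1.2-fold lower number from compound 2 to compound 3 (0.08 log units; within the scatter), that is, none beyond the scatter in either direction. In this assay compound 3 is therefore estimated at 1500 nM, with a range from 300 nM to 7000 nM.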

Compound 3, half-maximal inhibitory concentration: 430 nM
Compound 3: the middle estimate sits 3.5-fold (0.54 log units) above what was measured; low and high end bracket the measured number.
By their numbers in this assay, from the lowest: compound 3; then compound 2; then compound 1.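

With the carboxylic acid held constant, the group on the phenyl proves able to move the result in this assay: the exchange gives a 4.2-fold lower number from compound 2 to compound 3 (0.62 log units; beyond the scatter). Within the data shown here, this is the first change on the shared core that can be read in one place, and it shows that piperidin-1-yl, a non-aromatic ring, can give way to the larger ((pyrimidin-4-yl)carbonyl)amino, which brings an aromatic ring and a hydrogen-bond donor, with the number falling rather than rising. No measurement is available that explains this step, and it stays a plain observation for this single pair.

The compounds shown leave open which part of the entering group goes with the lower number: an acetylamino or a benzoylamino group in the same place would separate the amide link from the pyrimidine ring. The contribution of the carboxylic acid also stays unresolved, compound 1 and compound 2 differing in two places, and a methylamide carrying piperidin-1-yl on the phenyl would be needed to read that change alone.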